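Cytotoxicity Limits Across Two Related Compound Pairs

The source may report more compounds than this note shows. Statements on the series, on what has been measured and on what is new or still open speak of the compounds shown alone.

Compound 1 `CC(=O)c1ccc2[nH]c(-c3ccc(Cl)cc3)nc2c1` was examined in an ADME assay on BHK-21 cells (Mesocricetus auratus) for cytotoxicity, read by MTT assay; a lower number here means that less compound is tolerated, a higher number that more compound is tolerated. Compound 1 gives > 100000 nM, which is a limit of the assay rather than a number. Compound 2 `CC(=O)c1ccc2[nH]c(-c3ccc(C(F)(F)F)cc3)nc2c1` differs from compound 1 by trifluoromethyl in place of chloro on an aromatic carbon. In this assay compound 2 gives > 100000 nM, again a limit. The step that the two limits leave unreadable from compound 1 to compound 2 is therefore not readable. Compound 3 `C/C(=N\NC(N)=S)c1ccc2[nH]c(-c3ccc(Cl)cc3)nc2c1` has a different core, the difference being (a group of 7 heavy atoms (3 carbon, 3 nitrogen, 1 sulfur; no ring) in place of a group of 3 heavy atoms (2 carbon, 1 oxygen; no ring), on an aromatic carbon). In this assay compound 3 gives > 100000 nM, also a limit. The step that the two limits leave unreadable from compound 1 to compound 3 is likewise not readable. Compound 4 `C/C(=N\NC(N)=S)c1ccc2[nH]c(-c3ccc(C(F)(F)F)cc3)nc2c1` is not yet measured and differs from compound 3 by trifluoromethyl in place of chloro on an aromatic carbon, the same change as that from compound 1 to compound 2. Because the limit of > 100000 nM in this assay, at which 3 of the 3 values shown sit, holds for every measured compound here, compound 4 is expected to sit at that limit as well, an estimated step that the limit leaves unreadable from compound 3 to compound 4. The estimated value for compound 4 is 150000 nM.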

Compound 4, half-maximal cytotoxic concentration: 5000 nM
Compound 4: the middle estimate sits 30-fold (1.48 log units) above what was measured, and the stated range ends above it.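

In this assay, trifluoromethyl in place of chloro on the core of compound 3 brings an at least 20-fold lower number from compound 3 to compound 4 (1.30 log units; beyond the scatter), so this change is not silent on that core. With trifluoromethyl held fixed, the group of 7 heavy atoms in place of the group of 3 heavy atoms brings an at least 20-fold lower number from compound 2 to compound 4 (1.30 log units; beyond the scatter), so the low value appears only where both features are present among these compounds. This does not show how far the change carries from one core to another, as the same change on the core of compound 1 and the other steps between limits cannot be read: the limit of > 100000 nM in this assay, at which 3 of the 4 values shown sit.

On these data alone, whether the size of the step on the core of compound 3 is specific to trifluoromethyl remains open. As far as these compounds go, how a methoxy group, an amine or a carboxylic acid in that place would read on either core also remains open.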